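Swapping Fluoro for Nitro on Compound 2

A few compounds are considered here, and "the series" means these few. Any claim that something is new, unique, unknown or untested is made for them only; others in the source may bear on it.

Measured so far:
- compound 1 `O=C1Nc2ccc(F)cc2/C1=C\C(=O)c1ccc(O)cc1F`: 3440 nM
- compound 2 `O=C1Nc2ccc(F)cc2/C1=C\C(=O)c1ccc(C2CCCCC2)cc1`: 2840 nM

These two numbers come from a functional assay on HepG2 cells (Homo sapiens) for inhibition, read by sulforhodamine B assay, with a stated time of 3 days; on this read-out higher numbers stand for weaker inhibition and lower numbers for stronger inhibition. Compound 2 stands at 2840 nM, within the usual scatter of compound 1 at 3440 nM, so the pair cannot be ranked.

The next molecule is compound 3 `O=C1Nc2ccc([N+](=O)[O-])cc2/C1=C\C(=O)c1ccc(C2CCCCC2)cc1`. It keeps the rest of compound 2 but has nitro in place of fluoro on an aromatic carbon. The two measured compounds differ in more than one place, so the data hold no direct guide to this swap. For the measured compounds named here, with no measured precedent, no step beyond the scatter is expected in this assay, and no firm direction can be called. The expected change is a 1.1-fold lower number from compound 2 to compound 3 (0.06 log units; within the scatter).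

For compound 3 the estimate is 2500 nM, with an expected range from 800 nM to 8000 nM.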

Compound 3, half-maximal inhibitory concentration: 3990 nM
Compound 3: middle estimate off by 1.6-fold (0.20 log units), on the low side; low and high end bracket the measured number.
By their numbers in this assay, from the lowest: compounds 2, 1 and 3 (each within the scatter of the next).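

For the compounds shown here, this pair gives the first direct reading of this position, an aromatic carbon in the fused two-ring part of the molecule, with the rest of the structure held fixed. In this assay nitro in place of fluoro gives a 1.4-fold higher number from compound 2 to compound 3 (0.15 log units; within the scatter) and so stays within the scatter, even though nitro brings 3 heavy atoms and 2 hydrogen-bond acceptors where fluoro has 1 heavy atom and none. No measurement here offers an explanation for this result.

The compounds shown leave open whether another group at this position, such as an amine or a carboxylic acid, would move the number beyond the scatter. They also leave open whether nitro and fluoro would stay this close with the cyclohexyl-bearing end of the molecule changed.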